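Nitro for chloro on a hydroxamic acid scaffold

This account rests on a few compounds, and the source may have more. Where it says the series, first, only, none or still open, it means among the compounds named here.

This account concerns four small hydroxamic acids measured in an ADME assay on Huh-7 cells (Homo sapiens) for cytotoxicity, read by MTT assay, with a stated time of 72 h; on this read-out lower numbers stand for higher toxicity in this test and higher numbers for lower toxicity in this test. Compound 1 `CN(O)C(=O)c1ccccc1O` gives > 800000 nM in this assay, which is a limit of the assay and not a number. Compound 2 `COc1ccccc1C(=O)N(C)O` likewise gives > 800000 nM in this assay, again a limit rather than a number. The change from compound 1 to compound 2 is a step that the two limits leave unreadable from compound 1 to compound 2, so it offers nothing that can be read. Going by the values given here, compound 3 `O=C(NO)c1ccccc1Cl` gives 330000 nM in this assay, the only actual number among the three measured compounds, the other two being (the limit of > 800000 nM in this assay, at which 2 of the 3 values shown sit).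

The step followed here leads from compound 3 to compound 4 `O=C(NO)c1ccccc1[N+](=O)[O-]`, the change being (nitro in place of chloro on an aromatic carbon). Among the compounds with values here, no measured step touches this change: the single measured step swaps methyl for hydrogen on an oxygen and is itself unreadable, so there is no precedent for what nitro in place of chloro does in this assay. With nothing pointing in either direction, the expected step from compound 3 to compound 4 in this assay is a 1.4-fold higher number from compound 3 to compound 4 (0.13 log units; within the scatter), that is, none beyond the scatter. Compound 4 is therefore estimated at 450000 nM in this assay, within a range from 150000 nM to 900000 nM.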

Compound 4, half-maximal cytotoxic concentration: 55000 nM
Estimate against measurement, compound 4: 8.2-fold (0.91 log units) above; measured number below the stated range.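

In this assay, going by these compounds alone, nitro in place of chloro on an aromatic carbon, ortho to a group of 4 heavy atoms, gives a 6.0-fold lower number from compound 3 to compound 4 (0.78 log units; beyond the scatter), and this is the first step that can be read, since the one earlier step cannot. It shows that this position is not indifferent in this test: changing the group there can move the number beyond the scatter, and this change moves it towards higher toxicity in this test. Within the data shown here, the single step shows the size and direction of this one change, but nothing given here explains it.

As far as these compounds go, whether other groups at this position, such as an amine, a carboxylic acid or a nitrile, would move the number in the same direction or by a similar amount remains open, as does whether the same change would have the same effect on the core of compound 1. Compound 1 and compound 2 offer no number for comparison, as each stands at a limit of the assay: the limit of > 800000 nM in this assay, at which 2 of the 4 values shown sit.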